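This account rests on a few compounds, and the source may have more. Where it says the series, first, only, none or still open, it means among the compounds named here.

Measured so far in a physicochemical assay for metabolic stability, read by LC-MS, in phosphate buffer, tested at 1 uM; on this read-out higher numbers stand for a longer-lived compound and lower numbers for a shorter-lived compound:

- compound 1, `CC(=O)N1CCN(S(=O)(=O)c2ccc(F)cc2)C(CO)C1`: >= 4 h
- compound 2, `CCOC(=O)C1CN(S(=O)(=O)c2ccc(F)cc2)CCN1C(C)=O`: >= 4 h

The value shown for compound 1, >= 4 h, is a limit of the assay and not a number. The value for compound 2, >= 4 h, is likewise a limit. Compound 1 thus stands at the limit of >= 4 h in this assay, at which 2 of the 2 values shown sit, and with both values shown being limits, nothing can be said about an order between compound 1 and compound 2.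

Compound 3, `CCOC(=O)C1CN(C(C)=O)CCN1S(=O)(=O)c1ccc(F)cc1`, has not yet been measured in this assay. It differs from compound 1 by ethoxycarbonyl in place of hydroxymethyl on a saturated ring carbon, in words: ethoxycarbonyl in place of hydroxymethyl on a saturated ring carbon.

Within the data shown here, no pair of measured compounds that differ in one place is available, so no measured step gives the size of such a change in this assay. Given that both values shown sit at the limit of >= 4 h in this assay, at which 2 of the 2 values shown sit, the step from compound 1 to compound 3 is expected to be small, a step that the limit leaves unreadable from compound 1 to compound 3, with no direction claimed beyond the scatter. For compound 3 the estimate in this assay is 5 h, in a range from 2.5 h to 10 h, and the result is expected most likely to come back again only as a limit.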

Compound 3, half-life: >= 4 h
Compound 3: a limit, no number; the forecaster's own chance of this, stated with the estimate: 70%; the middle value lies beyond the limit too.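

In this assay compound 3 gives >= 4 h, which is a limit of the assay and not a number. Among these compounds, no step between compound 1 and compound 3 can be read: the limit of >= 4 h in this assay, at which 3 of the 3 values shown sit. The compounds shown leave open how long any of them actually lasts in this assay, and so whether ethoxycarbonyl in place of hydroxymethyl on a saturated ring carbon changes the half-life at all.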